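This account rests on a few compounds, and the source may have more. Where it says the series, first, only, none or still open, it means among the compounds named here.

Of the compounds shown here, three have been measured in a functional assay on a cell-free system (plasma, Oryctolagus cuniculus) for inhibition of platelet-activating factor acetylhydrolase (Homo sapiens), tested at 100 nM; on this read-out higher numbers stand for more inhibition at the one concentration tested (going by the name of the read-out) and lower numbers for less inhibition. Compound 1, `CCCCCCCCN(C)C(=O)Cn1cc(Cc2cnc(OCc3ccccc3)nc2)c(=O)nc1SCc1ccc(F)cc1`, gives 8% in this assay. Within the data shown here, compound 2, `CCCCCCCCN(C)C(=O)Cn1cc(Cc2cnc(=O)n(CC)c2)c(=O)nc1SCc1ccc(F)cc1`, gives 5% in this assay; that number and the one for compound 1 lie within the usual scatter of each other, so no order between the two can be read from them. Compound 3, `CCCCCCCCCCCCN(C)C(=O)Cn1cc(Cc2cnc(O)nc2)c(=O)nc1SCc1ccc(F)cc1`, gives 39% in this assay, a number that stands beyond the scatter above both of the others. Compound 3 differs from compound 2 in more than one place, so its higher number cannot be tied to any single change.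

The step under consideration leads from compound 2 to compound 4, `CCCCCCCCN(C)C(=O)Cn1cc(Cc2cnc(=O)n(CC(=O)N3CCNC(=O)C3)c2)c(=O)nc1SCc1ccc(F)cc1`. The change is (3-oxopiperazin-1-yl)carbonyl in place of methyl on a saturated chain carbon bound to an aromatic nitrogen. Among the measured compounds shown here, nothing among the measured compounds shows what this kind of change does in this assay, and the only two compounds that share the shorter chain of compound 2 both sit at the low end.

Compound 4 is therefore expected to stay near compound 2, with a step of a number 5 percentage points higher from compound 2 to compound 4 (within the scatter) that is not expected to go beyond the scatter in either direction. In this assay compound 4 is estimated at 10%, with a range from 0% to 28%.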

Compound 4, a percentage reported as inhibition, at one concentration (the size of the read-out at that concentration, not a potency): 55%
Beside the measured number, compound 4's estimate is 45 percentage points below it, outside the stated range (above it).
By their numbers in this assay, from the lowest: compounds 2 and 1 (each within the scatter of the next); then compound 3; then compound 4.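

In this assay, the place on a saturated chain carbon bound to an aromatic nitrogen proves highly sensitive to what is attached there: (3-oxopiperazin-1-yl)carbonyl in place of methyl gives a number 50 percentage points higher from compound 2 to compound 4 (beyond the scatter), the first effect of a single change that can be read in this set. The chain on the amide is the same in compound 2 and compound 4, so that chain alone does not hold a compound at the low end of the read-out. The compounds shown offer no measured explanation for the size of this step.

On these data alone, it remains open which part of the entering group carries the gain: a simple dimethylamide, a morpholine amide or a piperazine amide on the same carbon would separate the carbonyl, the ring and the amide hydrogen, and a carboxylic acid there would test whether a ring is needed at all. Among these compounds, also open is whether the (3-oxopiperazin-1-yl)carbonyl group gives a similar step when combined with a longer chain on the amide, such as the one in compound 3.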